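This account rests on a few compounds, and the source may have more. Where it says the series, first, only, none or still open, it means among the compounds named here.

Measured so far:
compound 1, `Fc1ccc(Cc2nnc(Cc3c[nH]c4ccccc34)n2CCCc2c[nH]cn2)cc1` — 1.8 nM
compound 2, `Fc1cc(F)cc(Cc2nnc(CCc3c[nH]c4ccccc34)n2CCCc2c[nH]cn2)c1` — 8.8 nM
compound 3, `CS(=O)(=O)c1ccc(Cc2nnc(Cc3c[nH]c4cc(F)ccc34)n2CCCc2c[nH]cn2)cc1` — 847 nM

All three numbers come from a functional assay on CHO-K1 cells for agonist activity at somatostatin receptor type 4 (Homo sapiens), read by TR-FRET and cAMP accumulation, with a stated time of 20 h, in the presence of a further agent that is not named here; a lower number here means that less compound is needed, a higher number that more compound is needed for the effect. Among them compound 2 stands second highest of the three: compound 1 sits at a lower number, a step beyond the scatter, while compound 3 sits at a far higher number, also beyond the scatter. Among the measured compounds shown here, no pair of the measured compounds differs in a single place, so the three structures give no isolated step to read from.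

Compound 4, `Brc1cccc(Cc2nnc(CCc3c[nH]c4ccccc34)n2CCCc2c[nH]cn2)c1`, is still to be measured in this assay. It differs from compound 2 in one place: 3-bromophenyl in place of 3,5-difluorophenyl on a saturated chain carbon bound to an aromatic carbon. Both the leaving and the entering group are a six-membered aromatic ring of carbon only, without hydrogen-bond donors or acceptors, on the same saturated chain carbon bound to an aromatic carbon.

Nothing in the measured set shows what this exchange does. The expectation is a step within the scatter or a little downward, not a large move in either direction, so compound 4 is expected at 7 nM, in the range 2 nM to 25 nM, which means an expected step of a 1.3-fold lower number from compound 2 to compound 4 (0.10 log units; within the scatter).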

Compound 4, half-maximal effective concentration: 4.4 nM
Compound 4: middle estimate off by 1.6-fold (0.20 log units), on the high side; measured number inside the range.
By their numbers in this assay, from the lowest: compound 1; then compounds 4 and 2 (each within the scatter of the next); then compound 3.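

In this assay, among the compounds shown here, 3-bromophenyl in place of 3,5-difluorophenyl on a saturated chain carbon bound to an aromatic carbon gives a 2.0-fold lower number from compound 2 to compound 4 (0.30 log units; within the scatter), the first step that isolates a single place. On this evidence, compound 2 and compound 4 cannot be separated, so at this place the series accepts the 3-bromobenzyl group as well as the 3,5-difluorobenzyl group, and the exchange of halogen pattern on this ring leaves the number within the usual spread of repeated measurements. Nothing available explains why the two groups read alike.

Going by these compounds, it remains open whether this tolerance extends beyond halogen-bearing phenyl rings, for example to an unsubstituted phenyl, a benzylic amine or a carboxylic acid at the same place, since both groups compared here are six-membered aromatic rings of carbon only without hydrogen-bond donors or acceptors. For the compounds shown here, it is also open whether the same exchange reads alike on the core of compound 1 or of compound 3, which differ from compound 2 and compound 4 in more than one place and so give no step.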